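Loss of drawn configuration on the shared core

This account rests on a few compounds, and the source may have more. Where it says the series, first, only, none or still open, it means among the compounds named here.

Compound 2 `CC1=CC(=O)[C@]2(O[C@@H]2C(=O)CC(C)C)C(=O)N1` is one of two compounds with the same core examined here. In a functional assay on HeLa cells (Homo sapiens) for cytotoxicity, read by WST assay, with a stated time of 48 h (on this read-out higher numbers stand for weaker inhibition and lower numbers for stronger inhibition), compound 2 is recorded as "not determined" (no result reported), so it has no number of its own to stand on. Within the data shown here, the only measured value comes from compound 1 `Cc1cc2c(c(=O)[nH]1)OC(C(=O)CC(C)C)O2`. In this assay compound 1 gives > 100000 nM, which is a limit of the assay rather than a number, as the limit of > 100000 nM in this assay, at which 1 of the 2 values shown sits, records. Compound 3 `CC1=CC(=O)C2(OC2C(=O)CC(C)C)C(=O)N1` differs from compound 2 as follows: the two compounds have the same atoms and bonds; at least one stereo element is drawn with a configuration in one of them and without one in the other: 2 of 2 stereo elements differ; a stereocentre at a saturated ring carbon is drawn S in compound 2 and without a configuration in compound 3; a stereocentre at a saturated ring carbon is drawn S in compound 2 and without a configuration in compound 3. Among the measured compounds shown here, since both stereocentres keep their place and only the drawn configuration is removed, he expects no step in this assay beyond the usual scatter, in either direction. With compound 1 as the sole measured anchor, compound 3 is estimated at 100000 nM, within a range of 30000 nM to 300000 nM, and is expected most likely to be reported as a limit as well.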

Compound 3, half-maximal inhibitory concentration: 40500 nM
The estimate for compound 3 lay 2.5-fold (0.39 log units) above the measured number; low and high end bracket the measured number.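

Compound 2 has no number to set against compound 3 at 40500 nM, so no step can be read between them. The compounds shown leave open whether the drawn configuration on the shared core makes any difference in this assay.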